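Returning to the 1H-tetrazol-1-yl attachment

The source may hold more compounds than are shown below. What is called first, only, known or untested is meant among the compounds shown, and "the series" means these compounds.

compound 1 `CCCCCCCCc1ccc(OCC(=O)Cn2cnnn2)cc1`: 22%
compound 2 `CCCCCCCCc1ccc(OCC(=O)Cn2nnc(C)n2)cc1`: < 5%
compound 3 `CCCCCCCCc1ccc(OCC(=O)Cn2nnc(C(=O)OC)n2)cc1`: < 5%

All three readings come from an ADME assay on S9 fraction from liver (Rattus norvegicus) for metabolic stability, read by LC-MS, using NADPH, with a stated time of 30 min; a lower number here means that less of the compound is left, a higher number that more of the compound is left. Compound 3 stands at < 5%, which is a limit of the assay and not a number. This is the limit of < 5% in this assay, at which 2 of the 3 values shown sit.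

The next compound is compound 4 `CCCCCCCCc1ccc(OCC(=O)Cn2nnnc2SC)cc1`, and the change is 5-(methylsulfanyl)-1H-tetrazol-1-yl in place of 5-(methoxycarbonyl)-2H-tetrazol-2-yl on a saturated chain carbon bound to a carbonyl carbon. Here 5-(methylsulfanyl)-1H-tetrazol-1-yl takes the place of 5-(methoxycarbonyl)-2H-tetrazol-2-yl on a saturated chain carbon bound to a carbonyl carbon.

For the measured compounds named here, two measured steps lead away from the only measured compound with a 1H-tetrazol-1-yl group: a number at least 17 percentage points lower from compound 1 to compound 2 (beyond the scatter), and a number at least 17 percentage points lower from compound 1 to compound 3 (beyond the scatter). Both were beyond the scatter. A third step gives no size to work with: a step that the two limits leave unreadable from compound 2 to compound 3.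

Going by the values given here, compound 4 returns to the 1H-tetrazol-1-yl form, but it also carries a 5-(methylsulfanyl) group, and no measured compound shows what that group does. Compound 1 at 22% is therefore only a loose guide, so a partial recovery in this assay is expected, not a full one. The estimated change is a number at least 5 percentage points higher from compound 3 to compound 4 (that floor lies within the scatter), a modest upward move at best. Compound 4 is expected to give 10%, with an estimated range from 3% to 25%.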

Compound 4, percent of the compound remaining: 21%
Compound 4: middle estimate off by 11 percentage points, on the low side; low and high end bracket the measured number.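

In this assay, the 5-(methylsulfanyl)-1H-tetrazol-1-yl group on a saturated chain carbon bound to a carbonyl carbon gives a number at least 16 percentage points higher from compound 3 to compound 4 (beyond the scatter), and it also gives a number at least 16 percentage points higher from compound 2 to compound 4 (beyond the scatter). Both steps start from a limit of the assay and not from a number, so they give only a floor for the size of the change: the limit of < 5% in this assay, at which 2 of the 4 values shown sit.

What is new comes from the third step, methylsulfanyl in place of hydrogen on an aromatic carbon, which gives a number 1 percentage points lower from compound 1 to compound 4 (within the scatter): the tetrazole of the 1H-tetrazol-1-yl form can carry this group with no change beyond the scatter, while both compounds with a 2H-tetrazol-2-yl group stay at the limit.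

As far as these compounds go, compounds 2 and 4 differ in both the attachment and the group on the tetrazole, so it remains open whether a methylsulfanyl group on the 2H-tetrazol-2-yl form would also clear the limit. Also open, from the compounds shown here alone, is whether a phenyl group or an amine at that aromatic carbon of the 1H-tetrazol-1-yl form would keep the reading of compound 4, and which part of the shared core is lost during the incubation.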